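A few compounds are considered here, and "the series" means these few. Any claim that something is new, unique, unknown or untested is made for them only; others in the source may bear on it.

Two compounds measured so far in an ADME assay on TZM-b1 cells (Homo sapiens) for cytotoxicity, read by XTT assay, with a stated time of 3 days; on this read-out higher numbers stand for lower toxicity in this test and lower numbers for higher toxicity in this test
- compound 1 `Cc1nc(C(NC(=O)C(=O)Nc2ccc(F)c(Cl)c2)C2CCCCN2)sc1CO` with > 77800 nM as a limit
- compound 2 `Cc1nc(C(NC(=O)C(=O)Nc2ccc(F)c(F)c2)C2CCCCN2)sc1CO` with > 87000 nM as a limit

Compound 2 reads only as the limit > 87000 nM with no number behind it, and the same holds for compound 1. The change to compound 3 `Cc1nc(C(NC(=O)C(=O)Nc2ccc(C(F)(F)F)cc2)C2CCCCN2)sc1CO` is 4-(trifluoromethyl)phenyl in place of 3,4-difluorophenyl on an amide-type nitrogen on the shared core. Among the compounds with values here, the one measured step that bears on it is a step that the two limits leave unreadable from compound 1 to compound 2 and its size cannot be read, so it offers nothing to carry over. No step beyond the scatter is therefore expected in this assay and no direction can be given. The estimated at least 1.0-fold lower number from compound 2 to compound 3 (0.03 log units; that floor lies within the scatter) is expected to stay small for that reason. Compound 3 is expected at 80000 nM with an estimated range from 30000 nM to 130000 nM and the assay may well report only a limit again.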

Compound 3, half-maximal cytotoxic concentration: > 75500 nM
Compound 3: only a limit was reported; the forecaster's own chance of this, stated with the estimate: 75%; the middle value does not contradict the limit.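

Compound 3, like compound 1 and compound 2, is reported only as a limit in this assay, and the steps among these three compounds cannot be read. The compounds shown leave open whether exchanging the group on the amide-type nitrogen changes the half-maximal cytotoxic concentration at all, and where that concentration lies for each compound.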